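Branching the Acyl Chain in Glutamate Receptor Modulators

The source may report more compounds than this note shows. Statements on the series, on what has been measured and on what is new or still open speak of the compounds shown alone.

The measured compounds:
compound 1, `CCCC(=O)c1ccc(OCCCCOc2cc(C(=O)O)ccc2OC)c(C)c1O`, 496 nM;
compound 2, `COc1ccc(C(=O)O)cc1OCCCCOc1ccc(C(=O)CC(C)C)c(O)c1C`, 737 nM;
compound 3, `CCC(=O)c1ccc(OCCCCOc2ccc(F)c(C(=O)O)c2)c(C)c1O`, "not determined" (no result reported).

In an assay on HEK293 cells for positive allosteric modulation of metabotropic glutamate receptor 3 (Rattus norvegicus), read by thallium flux, with a stated time of 2.5 min (on this read-out higher numbers stand for an effect only at larger amounts of compound and lower numbers for an effect already at smaller amounts), compound 1 gives 496 nM. Compound 2 differs from compound 1 by methyl in place of hydrogen on a saturated chain carbon bound to two saturated chain carbons, and in this assay compound 2 gives 737 nM. The step of a 1.5-fold higher number from compound 1 to compound 2 (0.17 log units; within the scatter) lies within the scatter, so the two values cannot be told apart.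

Compound 3 carries a different core; the difference between the two cores is not broken down here. In this assay compound 3 has "not determined" (no result reported), so there is no starting point on its own side. Compound 4, `Cc1c(OCCCCOc2ccc(F)c(C(=O)O)c2)ccc(C(=O)C(C)C)c1O`, differs from compound 3 by methyl in place of hydrogen on a saturated chain carbon bound to a carbonyl carbon and a saturated chain carbon. This is the same kind of change as that from compound 1 to compound 2, but not the same: in the earlier pair the methyl enters on a saturated chain carbon bound to two saturated chain carbons, here on a saturated chain carbon bound to a carbonyl carbon and a saturated chain carbon.

Among the measured compounds shown here, with only one earlier example, and that one within the scatter, the expectation for compound 4 is that the change itself moves the number little. Since compound 3 is not measured, the estimate for compound 4 must rest on compound 1, which gives 496 nM, and on compound 2, which gives 737 nM; these two values mark the range seen so far. Compound 4 is therefore expected to give about 700 nM in this assay, with a wide span from 200 nM to 2500 nM. The span is wide: compound 3 has no number of its own in this assay, so the core of compound 3 has no measured anchor.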

Compound 4, half-maximal effective concentration: > 10000 nM
Compound 4: no number, only a limit (the forecaster's own chance of this, stated with the estimate: 15%); middle value at least 14-fold (1.15 log units) away from the limit.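

In this assay compound 4 gives > 10000 nM, which is a limit of the assay and not a number. Among the compounds shown here, compound 3 stands at "not determined" (no result reported), so no step between compound 3 and compound 4 can be read. The compounds shown leave open whether methyl in place of hydrogen on a saturated chain carbon bound to a carbonyl carbon and a saturated chain carbon changes the number on the core of compound 3.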